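Moving the Methoxy Group Around the Sulfonyl Aryl Ring

The source may report more compounds than this note shows. Statements on the series, on what has been measured and on what is new or still open speak of the compounds shown alone.

Compound 1 `COc1ccccc1S(=O)(=O)Nc1ccc(-c2nc3ccccc3o2)cc1` in an assay on cells for inhibition of HSP60/HSP10 (Homo sapiens), with a stated time of 60 min; a lower number here means a stronger inhibitor, a higher number a weaker inhibitor: > 100000 nM, a limit of the assay.
Compound 2 `O=S(=O)(Nc1ccc(-c2nc3ccccc3o2)cc1)c1ccc(F)cc1` in this assay: 73000 nM.
Compound 3 `COc1ccc(S(=O)(=O)Nc2ccc(-c3nc4ccccc4o3)cc2)cc1` in this assay: > 100000 nM, a limit of the assay.

Compound 3 therefore sits at the limit of > 100000 nM in this assay, at which 2 of the 3 values shown sit. Compound 4 `COc1cccc(S(=O)(=O)Nc2ccc(-c3nc4ccccc4o3)cc2)c1` differs from it by 3-methoxyphenyl in place of 4-methoxyphenyl on a sulfonyl sulfur. Among the compounds with values here, no measured step reads on moving a methoxy group between positions: a step that the two limits leave unreadable from compound 1 to compound 3, while an at least 1.3-fold lower number from compound 1 to compound 2 (0.13 log units; that floor lies within the scatter) and an at least 1.3-fold higher number from compound 2 to compound 3 (0.13 log units; that floor lies within the scatter) concern fluoro against methoxy and are floors within the scatter. No step beyond the scatter is expected for compound 4 in this assay. Compound 4 is estimated at 100000 nM, within 30000 nM to 300000 nM. The expected step is a number no higher from compound 3 to compound 4 (the limit leaves the size open), most likely reported again only as a limit.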

Compound 4, half-maximal inhibitory concentration: 80000 nM
Compound 4: middle estimate off by 1.3-fold (0.10 log units), on the high side; the measured number falls inside the stated range.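

Of the three methoxy compounds, only compound 4 gives a number rather than a limit in this assay, yet the readable floors, an at least 1.2-fold lower number from compound 3 to compound 4 (0.09 log units; that floor lies within the scatter) and an at least 1.2-fold lower number from compound 1 to compound 4 (0.09 log units; that floor lies within the scatter), show no step beyond the scatter. The change to the fluoro compound gives a 1.1-fold higher number from compound 2 to compound 4 (0.04 log units; within the scatter), so 3-methoxyphenyl and 4-fluorophenyl are not told apart. Compound 1 and compound 3 remain limits of the assay: the limit of > 100000 nM in this assay, at which 2 of the 4 values shown sit.

On these data alone, the true size of the steps from those two limits remains open. So does how an amine or a carboxylic acid on this sulfonyl aryl ring would read.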